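This account rests on a few compounds, and the source may have more. Where it says the series, first, only, none or still open, it means among the compounds named here.

Measured compounds:
Compound 1, `CCCn1c(=O)[nH]c2nc(-c3ccc(S(=O)(=O)N4CCN(c5ccc(Cl)cc5F)CC4)cc3)[nH]c2c1=O`: in an assay on CHO cells for displacement of a labelled ligand from adenosine receptor A1 (Homo sapiens), read by scintillation counting, with a stated time of 90 min, in the presence of a further agent that is not named here (a higher number here means a weaker inhibitor, a lower number a stronger inhibitor), compound 1 gives > 1000 nM, which is a limit of the assay and not a number.
Compound 2, `CCCn1c(=O)[nH]c2nc(-c3ccc(S(=O)(=O)N4CCN(C)CC4)cc3)[nH]c2c1=O`: in this assay compound 2 gives 334 nM.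
Compound 3, `CCCn1c(=O)[nH]c2nc(-c3ccc(S(=O)(=O)N4CCN(c5ccccc5Br)CC4)cc3)[nH]c2c1=O`: in this assay compound 3 gives > 1000 nM, again a limit of the assay.

Compound 3 thus stands only at a limit, a position it shares with one other value in the set (the limit of > 1000 nM in this assay, at which 2 of the 3 values shown sit). Going by the values given here, the one readable step that reaches compound 3 is an at least 2.9-fold higher number from compound 2 to compound 3 (0.47 log units; beyond the scatter); the step that the two limits leave unreadable from compound 1 to compound 3 cannot be sized. The same change of group, read in the other direction, appears as an at least 2.9-fold lower number from compound 1 to compound 2 (0.47 log units; beyond the scatter): in both cases the aryl group on the ring nitrogen sits at the weaker end.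

Compound 4, `CCCn1c(=O)[nH]c2nc(-c3ccc(S(=O)(=O)N4CCN(c5cccc(Br)c5)CC4)cc3)[nH]c2c1=O`, differs from compound 3 by 3-bromophenyl in place of 2-bromophenyl on an amine nitrogen in a ring. Among the compounds with values here, no measured pair compares a 2-bromophenyl with a 3-bromophenyl, so the step is expected to be none beyond the scatter, a step that the limit leaves unreadable from compound 3 to compound 4. Compound 4 is accordingly expected to give 2500 nM (range 800 nM to 8000 nM), most probably reported only as a limit.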

Compound 4, inhibition constant: > 1000 nM
Compound 4: no number, only a limit; the forecaster's own chance of this, stated with the estimate: 75%; the middle value is on the limit's open side.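

In this assay compound 4 gives > 1000 nM (a limit of the assay, not a number). The steps from compound 3 and from compound 1 to compound 4 cannot be read, so the change from 2-bromophenyl to 3-bromophenyl on the ring nitrogen yields no order between the two. Going by these compounds alone, what is new is that a second bromophenyl, with the same atoms joined differently, also stands apart from the methyl group, with an at least 2.9-fold higher number from compound 2 to compound 4 (0.47 log units; beyond the scatter) (the only readable step to compound 4), and all three aryl compounds now rest at one limit: the limit of > 1000 nM in this assay, at which 3 of the 4 values shown sit.

On these data alone, the order among the aryl groups remains open. Also open, as far as these compounds go, is how an ethyl group, a longer chain or a benzyl group on this nitrogen would compare with methyl and the aryl groups.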